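The source may hold more compounds than are shown below. What is called first, only, known or untested is meant among the compounds shown, and "the series" means these compounds.

Among the compounds with values here, in an ADME assay on MT4 cells (Homo sapiens) for cytotoxicity, read by MTT assay, with a stated time of 5 days (a lower number here means that less compound is tolerated, a higher number that more compound is tolerated), compound 1 `Cc1cccc(C)c1Oc1cc(Nc2ccc(C#N)cc2)[nH]c(=O)c1Br` gives 63000 nM, the higher of the two numbers so far and beyond the scatter from compound 2 `Cc1cc(C)c(Oc2cc(Nc3ccc([N+](=O)[O-])cc3)[nH]c(=O)c2)c(C)c1`, which gives 26000 nM. Compound 3 `Cc1cccc(C)c1Oc1cc(Nc2ccc(C#N)cc2)[nH]c(=O)c1Cl` has not yet been measured. It differs from compound 1 by a single exchange, chloro in place of bromo on an aromatic carbon. Within the data shown here, no measured pair shows this exchange, so the expectation in this assay rests on its small size, and no step beyond the scatter is expected. The estimated step is a 1.1-fold lower number from compound 1 to compound 3 (0.06 log units; within the scatter). Compound 3 is expected to give 55000 nM, with an estimated range of 22000 nM to 120000 nM.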

Compound 3, half-maximal cytotoxic concentration: 29000 nM
The estimate for compound 3 lay 1.9-fold (0.28 log units) above the measured number; measured number inside the range.
By their numbers in this assay, from the lowest: compounds 2 and 3 (each within the scatter of the next); then compound 1.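

In this assay, the exchange of bromo for chloro on this aromatic carbon, two atoms from the ring nitrogen, moves the number beyond the scatter (a 2.2-fold lower number from compound 1 to compound 3 (0.34 log units; beyond the scatter)). Within the data shown here, this is the first single-place comparison here, and it shows that the read-out responds to the halogen at this position, which compound 1 and compound 2, differing in more than one place, could not show. Nothing available explains the step. From the compounds shown here alone, how a methyl group or an amine at this position would compare with bromo and chloro remains open. So does whether this exchange would give a similar step on another core.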